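A few compounds are considered here, and "the series" means these few. Any claim that something is new, unique, unknown or untested is made for them only; others in the source may bear on it.

Going by the values given here, compound 3, `CN1[C@@H]2c3[nH]c4ccccc4c3C[C@H]1[C@H](C#N)N1[C@@H](CNC(=O)c3ccc4ccccc4n3)c3[nH]c4ccccc4c3C[C@@H]21`, stands lowest of the three numbers so far in a functional assay on A2780 cells (Homo sapiens) for cytotoxicity, read by MTT assay, with a stated time of 72 h (a higher number here means a weaker inhibitor, a lower number a stronger inhibitor), where compound 3 gives 60 nM. Compound 1, `COc1ccc(C(=O)NC[C@H]2c3[nH]c4ccccc4c3C[C@H]3[C@H]4c5[nH]c6ccccc6c5C[C@@H]([C@H](C#N)N23)N4C)cc1`, gives 320 nM in this assay, and compound 2, `CCc1ccc(C(=O)NC[C@H]2c3[nH]c4ccccc4c3C[C@H]3[C@H]4c5[nH]c6ccccc6c5C[C@@H]([C@H](C#N)N23)N4C)cc1`, gives 670 nM. The steps among them show that the group attached to the amide carbonyl matters: this assay shifts by a 2.1-fold higher number from compound 1 to compound 2 (0.32 log units; beyond the scatter), by a 5.3-fold lower number from compound 1 to compound 3 (0.73 log units; beyond the scatter), and by an 11-fold lower number from compound 2 to compound 3 (1.05 log units; beyond the scatter).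

Compound 4, `CN1[C@@H]2c3[nH]c4ccccc4c3C[C@H]1[C@H](C#N)N1[C@@H](CNC(=O)c3cc4ccccc4[nH]3)c3[nH]c4ccccc4c3C[C@@H]21`, differs from compound 3 in one place: 1H-indol-2-yl in place of quinolin-2-yl on a carbonyl carbon. Among the compounds with values here, no measured step trades one two-ring group for another, so the three steps only set the scale of what this attachment can do. The change from a single ring with a small substituent to the quinolin-2-yl group brought the two larger steps; swapping one fused two-ring group for a closely related one is expected to bring a smaller move. A step of a 1.7-fold higher number from compound 3 to compound 4 (0.22 log units; within the scatter) in this assay is therefore expected, most likely a slight weakening that may not clear the scatter. Compound 4 is estimated at 100 nM in this assay, within a range from 30 nM to 300 nM.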

Compound 4, half-maximal inhibitory concentration: 7100 nM
The estimate for compound 4 lay 71-fold (1.85 log units) below the measured number, and the stated range ends below it.
By their numbers in this assay, from the lowest: compound 3; then compound 1; then compound 2; then compound 4.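

Going by these compounds alone, the group on the carbonyl carbon turns out to be far more sensitive than the earlier compounds showed: in this assay, exchanging one two-ring group for another brings a 120-fold higher number from compound 3 to compound 4 (2.07 log units; beyond the scatter), the largest step in this set. A two-ring group therefore does not by itself give a low number, as 1H-indol-2-yl also falls behind both single-ring groups, with an 11-fold higher number from compound 2 to compound 4 (1.03 log units; beyond the scatter) and a 22-fold higher number from compound 1 to compound 4 (1.35 log units; beyond the scatter), while quinolin-2-yl stays ahead of them. No measurement here explains why two such similar groups differ so widely, and the change alters the ring size and the hydrogen-bond count together, so the data cannot assign the step to either difference.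

The compounds shown leave open whether the low number of compound 3 depends on the nitrogen of quinolin-2-yl or on its pair of six-membered rings, a question that naphthalen-2-yl, with rings of carbon only, would address. They also leave open whether the amide-type hydrogen of the indole ring matters, which 1-methyl-1H-indol-2-yl, carrying a methyl group on that ring nitrogen, would test.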